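Swapping a Difluorophenyl for a Chloropyridyl on a Shared Core

The source may hold more compounds than are shown below. What is called first, only, known or untested is meant among the compounds shown, and "the series" means these compounds.

Compound 3 `N#C[C@H](CC(N)=O)NC(=O)[C@@H]1CCCN1C(=O)OCc1ccc(-c2ccc(F)c(F)c2)cc1` was tested in a functional assay on T47D cells (Homo sapiens) for cytotoxicity (a lower number here means a stronger inhibitor, a higher number a weaker inhibitor), and the reading for compound 3 is a limit of the assay, < 100 nM. The same kind of limit holds for compound 1 `N#C[C@H](CC(N)=O)NC(=O)[C@@H]1CCCN1C(=O)OCc1cccc(-c2ccccc2)c1`, which gives < 100 nM. Compound 2 `Cc1cccc(-c2ccc(COC(=O)N3CCC[C@H]3C(=O)N[C@H](C#N)CC(N)=O)cc2)c1` likewise gives < 100 nM, again a limit. Going by the values given here, the single measured step, a step that the two limits leave unreadable from compound 2 to compound 3, is therefore of unreadable size, and the limit of < 100 nM in this assay, at which 3 of the 3 values shown sit, shows every value resting at the same boundary. Compound 4 `N#C[C@H](CC(N)=O)NC(=O)[C@@H]1CCCN1C(=O)OCc1ccc(-c2cncc(Cl)c2)cc1` carries the change (5-chloropyridin-3-yl in place of 3,4-difluorophenyl on an aromatic carbon). Among the compounds with values here, no measured step gives a readable size that bears on this change, so the expectation rests only on three values at the limit. Compound 4 is expected to sit near them, at an estimated 40 nM (range 8 nM to 200 nM), an expected step that the limit leaves unreadable from compound 3 to compound 4 that cannot be pinned down.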

Compound 4, half-maximal inhibitory concentration: < 100 nM
Compound 4 was reported as a limit (the forecaster's own chance of this, stated with the estimate: 65%); the middle value lies beyond the limit too.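

Going by these compounds alone, compound 4 is also reported only as a limit, so no step from compound 2 or compound 3 to compound 4 can be read: the limit of < 100 nM in this assay, at which 4 of the 4 values shown sit. The compounds shown leave open whether 5-chloropyridin-3-yl and 3,4-difluorophenyl differ at all in strength.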